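Side chain variation on the aryl ether of the coumarin amide

A few compounds are considered here, and "the series" means these few. Any claim that something is new, unique, unknown or untested is made for them only; others in the source may bear on it.

The series shares one core and differs only in the chain on the aromatic ether oxygen. Compound 1 `CC(C)=CCc1cc(C(=O)Nc2cc3ccc(OCCC4CCCCN4)c(C)c3oc2=O)ccc1O` gives 640 nM in a functional assay on SK-BR-3 cells (Homo sapiens) for antiproliferative activity; on this read-out higher numbers stand for weaker inhibition and lower numbers for stronger inhibition. Compound 2 `CC(C)=CCc1cc(C(=O)Nc2cc3ccc(OCC4CCN(C)C4)c(C)c3oc2=O)ccc1O` gives 920 nM in this assay, and compound 3 `CC(C)=CCc1cc(C(=O)Nc2cc3ccc(OCCCNCCO)c(C)c3oc2=O)ccc1O` gives 610 nM. Compound 2 carries the highest of the three numbers, but that position is not separated from the others: a 1.4-fold higher number from compound 1 to compound 2 (0.16 log units; within the scatter) and a 1.5-fold lower number from compound 2 to compound 3 (0.18 log units; within the scatter), and between the outer pair a 1.0-fold lower number from compound 1 to compound 3 (0.02 log units; within the scatter). Every exchange of the amine-bearing chain at this position has so far left the read-out within the scatter.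

Compound 4 `CC(C)=CCc1cc(C(=O)Nc2cc3ccc(OCCCNC4CCCCC4)c(C)c3oc2=O)ccc1O` is not yet measured. Relative to compound 2 the change is 2-(cyclohexylamino)ethyl in place of 1-methylpyrrolidin-3-yl on a saturated chain carbon bound to an oxygen on an aromatic ring. The closest precedents are the steps from compound 2 to compound 1 and to compound 3, both within the scatter, and compound 3 already carries an open-chain secondary amine of the same kind. No step beyond the scatter is therefore expected: a 1.3-fold lower number from compound 2 to compound 4 (0.12 log units; within the scatter) is the estimated move. Compound 4 is expected to give 700 nM, within the range 300 nM to 1700 nM.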

Compound 4, half-maximal inhibitory concentration: 660 nM
Estimate against measurement, compound 4: 1.1-fold (0.03 log units) above; the range from low to high includes it.
By their numbers in this assay, from the lowest: compounds 3, 1, 4 and 2 (each within the scatter of the next).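

The exchange holds even for a much larger substituent: 2-(cyclohexylamino)ethyl, with 9 heavy atoms and a six-membered carbon-only ring against 6 heavy atoms in 1-methylpyrrolidin-3-yl, stays within the scatter in this assay (a 1.4-fold lower number from compound 2 to compound 4 (0.14 log units; within the scatter)). On the amine nitrogen, cyclohexyl serves as well as 2-hydroxyethyl (a 1.1-fold higher number from compound 3 to compound 4 (0.03 log units; within the scatter)), and (cyclohexylamino)methyl matches piperidin-2-yl (a 1.0-fold higher number from compound 1 to compound 4 (0.01 log units; within the scatter)), so neither the hydroxyl of compound 3 nor the ring nitrogen of compound 1 is needed to keep the read-out at this level. No measurement at hand accounts for this flat response.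

As far as these compounds go, all four chains carry an amine, so a plain propoxy chain or a chain ending in a carboxylic acid remains open. Also open, from the compounds shown here alone, is whether a phenyl group on the amine nitrogen would stay within the scatter.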